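The source may report more compounds than this note shows. Statements on the series, on what has been measured and on what is new or still open speak of the compounds shown alone.

Working notes on the series.

Compound 1 `Cc1ccc([C@@H]2C[C@H](O)Cc3cc(F)ccc3N2)s1` carries a 5-methylthiophen-2-yl group on the saturated ring carbon and a fluoro group on the aromatic ring. In an ADME assay on THP-1 cells (Homo sapiens) for cytotoxicity (on this read-out higher numbers stand for lower toxicity in this test and lower numbers for higher toxicity in this test), compound 1 gives 312000 nM. Compound 2 `Cc1ccsc1[C@@H]1C[C@H](O)Cc2cc(F)ccc2N1` differs by 3-methylthiophen-2-yl in place of 5-methylthiophen-2-yl on a saturated ring carbon, and in this assay compound 2 gives 1810000 nM, a step of a 5.8-fold higher number from compound 1 to compound 2 (0.76 log units; beyond the scatter). Compound 3 `Cc1ccc([C@@H]2C[C@H](O)Cc3cc(OC(F)(F)F)ccc3N2)s1` differs from compound 1 by trifluoromethoxy in place of fluoro on an aromatic carbon; in this assay compound 3 gives 98000 nM, a step of a 3.2-fold lower number from compound 1 to compound 3 (0.50 log units; beyond the scatter), and it holds the lowest of the three numbers.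

Compound 4 `Cc1ccsc1[C@@H]1C[C@H](O)Cc2cc(OC(F)(F)F)ccc2N1` is not yet measured. It differs from compound 3 by 3-methylthiophen-2-yl in place of 5-methylthiophen-2-yl on a saturated ring carbon, the same change that separates compound 1 from compound 2, made on the core of compound 3 rather than on the core of compound 1. The two cores differ as described by trifluoromethoxy in place of fluoro on an aromatic carbon. The expectation for compound 4 in this assay is a step of a 4.6-fold higher number from compound 3 to compound 4 (0.66 log units; beyond the scatter), which rests on the earlier step of a 5.8-fold higher number from compound 1 to compound 2 (0.76 log units; beyond the scatter) seen with the same change. Compound 4 is therefore expected at about 450000 nM. The range for compound 4 is estimated to run from 150000 nM to 1500000 nM.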

Compound 4, half-maximal cytotoxic concentration: 89700 nM
Beside the measured number, compound 4's estimate is 5.0-fold (0.70 log units) above it; the measured number lies below the stated range.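

With trifluoromethoxy on the aromatic ring, 3-methylthiophen-2-yl in place of 5-methylthiophen-2-yl gives a 1.1-fold lower number from compound 3 to compound 4 (0.04 log units; within the scatter) in this assay, so the step seen with fluoro does not carry over to this core: the same change on two cores in this assay, a 5.8-fold higher number (0.76 log units; beyond the scatter) from compound 1 to compound 2 and a 1.1-fold lower number (0.04 log units; within the scatter) from compound 3 to compound 4, 6.3-fold (0.80 log units) apart, beyond the scatter of two such steps

Read the other way, trifluoromethoxy in place of fluoro gives a 20-fold lower number from compound 2 to compound 4 (1.30 log units; beyond the scatter), so that change also depends on the core that carries it: the same change on two cores in this assay, a 3.2-fold lower number (0.50 log units; beyond the scatter) from compound 1 to compound 3 and a 20-fold lower number (1.30 log units; beyond the scatter) from compound 2 to compound 4, 6.3-fold (0.80 log units) apart, beyond the scatter of two such steps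

The two changes therefore do not add up across these four compounds, but this single set of four does not show what produces the dependence or how either change would behave on any further core.

The compounds shown leave open whether the same dependence appears with a chloro group or a nitrile on that aromatic carbon. They also leave open whether an ethyl group in place of the thiophene methyl would follow the fluoro pair, the trifluoromethoxy pair or neither.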